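Lengthening an Alkyl Chain and Buffer Solubility

A few compounds are considered here, and "the series" means these few. Any claim that something is new, unique, unknown or untested is made for them only; others in the source may bear on it.

Compound 1 `CCCCCCCCN(C)/N=N/c1ccc(C(=O)O)cc1`: 171000 nM
Compound 2 `CCCCCCCN(C)/N=N/c1ccc(C(=O)O)cc1`: 410000 nM
Compound 3 `CCCN(C)/N=N/c1ccc(C(=O)O)cc1`: 36800000 nM

These three values come from a physicochemical assay for solubility, in phosphate buffer, at pH 7.4; a lower number here means a less soluble compound, a higher number a more soluble compound. Compound 4 `CCCCN(C)/N=N/c1ccc(C(=O)O)cc1` has not yet been measured in this assay. It differs from compound 3 by methyl in place of hydrogen on a saturated chain carbon, three bonds along the chain from an amine nitrogen. The same kind of change has been measured once already: compound 1 differs from compound 2 by methyl in place of hydrogen on a saturated chain carbon, seven bonds along the chain from an amine nitrogen, with a 2.4-fold lower number from compound 2 to compound 1 (0.38 log units; beyond the scatter). The place is not identical, since in that pair the carbon lies seven bonds along the chain from the amine nitrogen, here three bonds along it. The cores of compound 2 and compound 3 themselves differ by hydrogen in place of butyl on a saturated chain carbon, three bonds along the chain from an amine nitrogen, with a 90-fold higher number from compound 2 to compound 3 (1.95 log units; beyond the scatter). For compound 4 a step of similar size to the earlier one is expected, a 3.1-fold lower number from compound 3 to compound 4 (0.49 log units; beyond the scatter), because a 90-fold higher number from compound 2 to compound 3 (1.95 log units; beyond the scatter) spreads across four added carbons at a fairly even rate. Compound 4 is therefore estimated at 12000000 nM, between 5000000 nM and 25000000 nM.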

Compound 4, solubility: 15500000 nM
Beside the measured number, compound 4's estimate is 1.3-fold (0.11 log units) below it; the range from low to high includes it.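

Going from propyl to butyl in this assay gives a 2.4-fold lower number from compound 3 to compound 4 (0.38 log units; beyond the scatter), and the same added methyl on the longer chain of compound 2 gave a 2.4-fold lower number from compound 2 to compound 1 (0.38 log units; beyond the scatter), so this change carried over between these two cores with the same direction and printed size. Among the compounds shown here, the wider gaps, a 38-fold higher number from compound 2 to compound 4 (1.58 log units; beyond the scatter) and a 91-fold higher number from compound 1 to compound 4 (1.96 log units; beyond the scatter), run the same way, with shorter chains giving higher numbers and no compound here going against that. These are only two pairs at two places on one chain, so they show no general rule, and nothing shown explains the steps.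

From the compounds shown here alone, whether a hexyl chain would fit the same pattern stays open. So does whether a branched chain such as isopropyl, or an amide in place of the carboxylic acid, would keep it.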